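The source may hold more compounds than are shown below. What is called first, only, known or untested is meant among the compounds shown, and "the series" means these compounds.

Measured so far in a functional assay on B16-F10 cells (Mus musculus) for inhibition, read by MTT assay, with a stated time of 72 h; a lower number here means a stronger inhibitor, a higher number a weaker inhibitor:
compound 1, `Cc1ccc(-c2nc(SCc3cn(CC(=O)NC(=O)Nc4ccccn4)nn3)nc(Nc3ccc(C(C)C)cc3)c2C#N)cc1`, gives 35 nM.
compound 2, `COc1ccccc1Nc1nc(SCc2cn(CC(=O)NC(=O)Nc3ccccn3)nn2)nc(-c2ccc(C)cc2)c1C#N`, gives 8580 nM.
compound 3, `Cc1ccc(-c2nc(SCc3cn(CC(=O)NC(=O)Nc4ccccn4)nn3)nc(Nc3cccc(Cl)c3)c2C#N)cc1`, gives 7580 nM.

Compound 1 gives the lowest number of the three and is the strongest inhibitor among them: the step of a 250-fold higher number from compound 1 to compound 2 (2.39 log units; beyond the scatter) and the step of a 220-fold higher number from compound 1 to compound 3 (2.34 log units; beyond the scatter) are both far beyond the scatter, while compound 2 and compound 3 lie within the scatter of each other, as the step of a 1.1-fold lower number from compound 2 to compound 3 (0.05 log units; within the scatter) shows. Both large steps exchange the aryl group that sits on the ring nitrogen of the shared core; they say nothing about the other aryl group attached to that core.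

Compound 4, `CC(C)c1ccc(Nc2nc(SCc3cn(CC(=O)NC(=O)Nc4ccccn4)nn3)nc(-c3ccc(Cl)cc3)c2C#N)cc1`, has not yet been measured. It differs from compound 1 in one place only: chloro in place of methyl on an aromatic carbon. Going by the values given here, this alters a ring that none of the measured steps touches, so nothing among the three measured compounds bears directly on this exchange. With no measured guide, the expectation is a step that stays within the scatter, with compound 4 close to compound 1 in this assay. The estimate for compound 4 is 50 nM, with a range from 15 nM to 200 nM, which corresponds to an expected step of a 1.4-fold higher number from compound 1 to compound 4 (0.15 log units; within the scatter).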

Compound 4, half-maximal inhibitory concentration: 1590 nM
Compound 4: middle estimate off by 32-fold (1.50 log units), on the low side; measured number outside the range, above it.
By their numbers in this assay, from the lowest: compound 1; then compound 4; then compounds 3 and 2 (each within the scatter of the next).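

In this assay, going by these compounds alone, the exchange of 4-methylphenyl for 4-chlorophenyl gives a 45-fold higher number from compound 1 to compound 4 (1.66 log units; beyond the scatter) and so brings a large step at a ring that no earlier step touched. The earlier large steps all came from changing the aryl group on the ring nitrogen, whereas here that group stays as 4-isopropylphenyl, which shows that the number also depends strongly on the other aryl group on the shared core. Only one heavy atom is exchanged in this step, and the counts of rings, hydrogen-bond donors and hydrogen-bond acceptors stay the same. Nothing available explains why chloro and methyl differ so much at this position.

With only methyl and chloro shown at this position, it remains open how a methoxy group, a bare hydrogen or a longer chain such as ethyl would read there. Going by these compounds, it also remains open whether the exchange of methyl for chloro would bring a step of similar size when the 2-methoxyphenyl of compound 2 or the 3-chlorophenyl of compound 3 sits on the nitrogen.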